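This account rests on a few compounds, and the source may have more. Where it says the series, first, only, none or still open, it means among the compounds named here.

Compound 1 `CCCc1ccc(NC2=CC(=O)c3c(nc4n3[C@H]3OC[C@@H](O)[C@H]3OC4)C2=O)cc1` gives in a functional assay on MCF7 cells (Homo sapiens) for inhibition, read by sulforhodamine B assay (on this read-out higher numbers stand for weaker inhibition and lower numbers for stronger inhibition), the limit > 4000 nM, not a number.
Compound 2 `COc1cccc(NC2=CC(=O)c3nc4n(c3C2=O)[C@H]2OC[C@@H](O)[C@H]2OC4)c1` gives in this assay the limit > 4000 nM, again not a number.

Compound 1 thus stands only at a limit, and both values shown sit there (the limit of > 4000 nM in this assay, at which 2 of the 2 values shown sit). Compound 3 `CCc1ccc(NC2=CC(=O)c3c(nc4n3[C@H]3OC[C@@H](O)[C@H]3OC4)C2=O)cc1` differs from compound 1 by hydrogen in place of methyl on a saturated chain carbon, two bonds along the chain from an aromatic carbon. No step between measured compounds is shown, so the effect of this change is unknown. The expected step that the limit leaves unreadable from compound 1 to compound 3 is none beyond the scatter, with a further limit most likely. Compound 3 is expected at 8000 nM, with a range from 2500 nM to 30000 nM.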

Compound 3, half-maximal inhibitory concentration: 8990 nM
Beside the measured number, compound 3's estimate is 1.1-fold (0.05 log units) below it; the measured number falls inside the stated range.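

The step from compound 1 to compound 3 cannot be read, because compound 1 stands only at a limit: the limit of > 4000 nM in this assay, at which 2 of the 3 values shown sit.
How far the change from 4-propylphenyl to 4-ethylphenyl moves the value in this assay stays open with the compounds shown.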